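This account rests on a few compounds, and the source may have more. Where it says the series, first, only, none or still open, it means among the compounds named here.

In a functional assay on K562 cells (Homo sapiens) for cytotoxicity, read by MTT assay, with a stated time of 24 h (on this read-out higher numbers stand for weaker inhibition and lower numbers for stronger inhibition), compound 1 (`CN1C/C(=C\c2cccc([N+](=O)[O-])c2)C(=O)/C(=C/c2ccc(Cl)cc2Cl)C1`) gives 12400 nM, compound 2 (`CN1C/C(=C\c2ccc(F)cc2)C(=O)/C(=C/c2ccc(C#N)cc2)C1`) gives 11300 nM and compound 3 (`CN1C/C(=C\c2ccc(Cl)cc2)C(=O)/C(=C/c2ccc(C#N)cc2)C1`) gives 13300 nM, so compound 3 lies within the scatter of both others. Compound 4 (`CN1C/C(=C\c2ccc(C#N)cc2)C(=O)/C(=C/c2ccc(Cl)cc2Cl)C1`) follows from compound 3 by chloro in place of hydrogen on an aromatic carbon, turning 4-chlorophenyl into 2,4-dichlorophenyl. Within the data shown here, no measured step makes this change. The closest one, a 1.2-fold higher number from compound 2 to compound 3 (0.07 log units; within the scatter), is a different exchange on an aromatic carbon. Compound 1 already carries 2,4-dichlorophenyl and gives 12400 nM. No shift beyond the scatter is therefore expected in this assay, and the expected step is a 1.2-fold lower number from compound 3 to compound 4 (0.08 log units; within the scatter). Compound 4 is estimated at 11000 nM, with an expected range from 5500 nM to 22000 nM.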

Compound 4, half-maximal inhibitory concentration: 11900 nM
Beside the measured number, compound 4's estimate is 1.1-fold (0.03 log units) below it, and the stated range covers the measured number.
By their numbers in this assay, from the lowest: compounds 2, 4, 1 and 3 (each within the scatter of the next).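

In this assay, chloro on the aromatic carbon ortho to a large group, turning 4-chlorophenyl into 2,4-dichlorophenyl, gives a 1.1-fold lower number from compound 3 to compound 4 (0.05 log units; within the scatter) and so leaves the number unmoved at this position. The other two exchanges give a 1.1-fold higher number from compound 2 to compound 4 (0.02 log units; within the scatter) and a 1.0-fold lower number from compound 1 to compound 4 (0.02 log units; within the scatter) and also show no shift, with 2,4-dichlorophenyl replacing 4-fluorophenyl in the first and 4-cyanophenyl replacing 3-nitrophenyl in the second. No measurement on hand accounts for this flatness. The compounds shown leave open whether an amine or a carboxylic acid on this ring would carry the number beyond the scatter.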